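The compounds below may be only part of what the source reports. "The series", "measured", "known", "first", "only" and "open" are said of these compounds alone.

Of the compounds shown here, three sharing one core have been measured in a physicochemical assay for acid dissociation. Compound 1 `COc1ccc(Oc2ccc3c(NCCCNCc4cc(F)ccc4OC)ccnc3c2)cc1` gives 9.28, compound 2 `COc1ccc(F)cc1CNCCCNc1ccnc2cc(CCc3ccccc3)ccc12` gives 9.47, and compound 3 `CCC(CC)c1ccc2c(NCCCNCc3cc(F)ccc3OC)ccnc2c1` gives 9.47. Compound 3 stands level with compound 2, the two together the highest of the three numbers, and compound 1 lies furthest from it; both steps, a number 0.19 log units higher from compound 1 to compound 3 (within the scatter) and no change at the digits printed from compound 2 to compound 3 (within the scatter), fall within the scatter. Compound 4 `COc1ccc(F)cc1CNCCCNc1ccnc2cc(Oc3ccccc3OC)ccc12` differs from compound 3 by 2-methoxyphenoxy in place of pentan-3-yl on an aromatic carbon. The step that bears on this change is a number 0.19 log units higher from compound 1 to compound 3 (within the scatter), here read in the reverse sense, and it stays within the scatter. Compound 4 is therefore expected to give 9.3 in this assay, within 9.05 to 9.55, a step of a number 0.17 log units lower from compound 3 to compound 4 (within the scatter) that is expected to stay within the scatter.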

Compound 4, acid dissociation constant: 9.28
Compound 4: the middle estimate sits 0.02 log units above what was measured, and the stated range covers the measured number.
By their numbers in this assay, from the lowest: compounds 1, 4, 2 and 3 (each within the scatter of the next).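

In this assay, 2-methoxyphenyl in place of 4-methoxyphenyl on the ether oxygen gives no separation between the two isomeric ethers (no change at the digits printed from compound 1 to compound 4 (within the scatter)). The 2-methoxyphenoxy group also stays within the scatter of both carbon-linked groups, pentan-3-yl (a number 0.19 log units lower from compound 3 to compound 4 (within the scatter)) and phenethyl (a number 0.19 log units lower from compound 2 to compound 4 (within the scatter)). Across these four compounds, this aromatic carbon has therefore taken branched alkyl, phenethyl and both aryl ether groups without a step beyond the scatter.

From the compounds shown here alone, whether an amine or a carboxylic acid at this carbon would keep the number within the scatter remains open. Nothing available here accounts for how closely these numbers agree.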